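The compounds below may be only part of what the source reports. "The series", "measured", "known", "first", "only" and "open" are said of these compounds alone.

Working notes on a small set built around one shared core, the four members differing only in the group on an oxygen on an aromatic ring and in how the two cores are joined. Compound 1 `CC1(/C=C/c2ccccc2O)C=CC(=O)O1` and compound 3 `COc1ccccc1/C=C/C1(C)C=CC(=O)O1` make one pair; compound 2 `CC1(/C=C/c2cccc(O)c2)C=CC(=O)O1` and the not yet measured compound 4 `COc1cccc(/C=C/C2(C)C=CC(=O)O2)c1` make the other. In a functional assay on UACC-62 cells (Homo sapiens) for inhibition, read by sulforhodamine B assay, with a stated time of 48 h (a higher number here means a weaker inhibitor of growth, a lower number a stronger inhibitor of growth), compound 1 gives 92500 nM, while compound 3 gives 31000 nM in this assay. The change between them, (methyl in place of hydrogen on an oxygen on an aromatic ring), produced the step of a 3.0-fold lower number from compound 1 to compound 3 (0.47 log units; beyond the scatter). Compound 2 gives 108000 nM in this assay, which sits close to the value of compound 1; the difference between the core of compound 1 and the core of compound 2 is not broken down here. Compound 4 carries the same change relative to compound 2, (methyl in place of hydrogen on an oxygen on an aromatic ring), and the place where it occurs is described in the same words for both pairs, so this is taken as the same change in a second setting. Among the measured compounds shown here, only one measured instance of it exists, that from compound 1 to compound 3, so the expectation for compound 4 rests on a single precedent and on the value of compound 2. Starting from compound 2 at 108000 nM, the step to compound 4 is expected to be about a 3.0-fold lower number from compound 2 to compound 4 (0.48 log units; beyond the scatter). Compound 4 is therefore estimated at 36000 nM in this assay, with a plausible span from 15000 nM to 90000 nM.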

Compound 4, concentration for total growth inhibition: 55800 nM
For compound 4 the middle estimate is 1.6-fold (0.19 log units) below the measured one; the range from low to high includes it.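

Replacing hydroxy with methoxy on the core of compound 2 gives a 1.9-fold lower number from compound 2 to compound 4 (0.29 log units; within the scatter) in this assay, so this step taken alone cannot be told apart from no change. Set beside the earlier step, it does not differ measurably from it: the same change on two cores in this assay, a 3.0-fold lower number (0.47 log units; beyond the scatter) from compound 1 to compound 3 and a 1.9-fold lower number (0.29 log units; within the scatter) from compound 2 to compound 4, 1.5-fold (0.19 log units) apart, within the scatter of two such steps. The hydroxy to methoxy change can therefore be carried from the core of compound 1 to the core of compound 2 without a detectable difference in step size, and the number falls on both cores, but this rests on two pairs only and does not show that the change reliably lowers the number on the core of compound 2 or that it would behave the same way on any further core.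

The compounds shown leave open whether a longer chain on the same oxygen, such as ethyl or propyl, or an acetyl group in place of the methyl, would follow the same course on either core. They also leave open how an amine or a fluorine, set on the aromatic ring in place of the hydroxy or methoxy group, would compare in this series.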